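The source may hold more compounds than are shown below. What is called first, only, known or untested is meant among the compounds shown, and "the series" means these compounds.

In a functional assay on NCI-H460 cells (Homo sapiens) for antiproliferative activity, read by MTT assay, with a stated time of 48 h (on this read-out lower numbers stand for stronger inhibition and higher numbers for weaker inhibition), compound 1 `CCCCCCC1(O)C(=O)Nc2ccc(Nc3ccc(C)cc3)cc21` gives > 100000 nM, which is a limit of the assay and not a number. Compound 2 `CCCCCCC1(O)C(=O)Nc2ccc(Nc3ccc(Cl)cc3)cc21` reads 30300 nM. Going by the values given here, compound 3 `CCCCC1(O)C(=O)Nc2ccc(Nc3ccc(C(F)(F)F)cc3)cc21` has the lowest number so far, at 12000 nM. Compound 4 `CCCCCCC1(O)C(=O)Nc2ccc(Nc3ccc(C(F)(F)F)cc3)cc21` differs from compound 3 by ethyl in place of hydrogen on a saturated chain carbon, four bonds along the chain from a saturated ring carbon. Among the compounds with values here, the one measured step, an at least 3.3-fold lower number from compound 1 to compound 2 (0.51 log units; beyond the scatter), swaps methyl for chloro on an aromatic carbon and leaves the chain untouched, so it bears only loosely on this change. No shift beyond the scatter is therefore expected in this assay. The estimated step is a 1.3-fold higher number from compound 3 to compound 4 (0.10 log units; within the scatter). For compound 4 the expected value is 15000 nM, with an estimated range of 5000 nM to 45000 nM.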

Compound 4, half-maximal inhibitory concentration: 18800 nM
Estimate against measurement, compound 4: 1.3-fold (0.10 log units) below; the range from low to high includes it.
By their numbers in this assay, from the lowest: compounds 3, 4 and 2 (each within the scatter of the next, the first and the last beyond it). At a limit, above all of these: compound 1.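

Ethyl in place of hydrogen on the saturated chain gives a 1.6-fold higher number from compound 3 to compound 4 (0.19 log units; within the scatter) and so does not separate the two chain lengths. With the longer chain kept, trifluoromethyl in place of chloro on an aromatic carbon gives a 1.6-fold lower number from compound 2 to compound 4 (0.21 log units; within the scatter) and does not separate these two groups either. Trifluoromethyl in place of methyl gives an at least 5.3-fold lower number from compound 1 to compound 4 (0.72 log units; beyond the scatter) and is the only clear step here, though the value of compound 1 is a limit and not a number: the limit of > 100000 nM in this assay, at which 1 of the 4 values shown sits.

As far as these compounds go, what a longer chain or an amine in its place would do stays open, as does a nitrile in place of trifluoromethyl on the aromatic carbon.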